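The source may report more compounds than this note shows. Statements on the series, on what has been measured and on what is new or still open speak of the compounds shown alone.

Compound 1 `CC(C)(C)C1=C(C(=O)O)N2C(=O)[C@H](CO)[C@H]2O1` is measured in an ADME assay, in phosphate buffer, at 28 degrees C, at pH 7.0 (a higher number here means that the compound lasts longer, a lower number that the compound disappears faster), and gives 5 h. Among the three compounds with numbers, compound 1 stands second highest. Compound 2 `CC(C)(C)C1=C(C(=O)O)N2C(=O)[C@H]([C@H](O)CCc3ccncc3)[C@H]2O1` gives 13.7 h in this assay, and compound 3 `CC(C)(C)C1=C(C(=O)O)N2C(=O)[C@H](CO)[C@@H]2O1` gives 2.4 h in this assay. Both steps from compound 1 are modest: a 2.7-fold higher number from compound 1 to compound 2 (0.44 log units; beyond the scatter), and a 2.1-fold lower number from compound 1 to compound 3 (0.32 log units; beyond the scatter), the latter resting on (the fact that compounds 1 and 3 differ only in the configuration as drawn). Compound 4 `CC(C)(C)C1=C(C(=O)O)N2C(=O)[C@H]([C@@H](O)CCc3ccccc3)[C@H]2O1` has not yet been measured; it differs from compound 1 in one place: phenethyl in place of hydrogen on a saturated chain carbon bound to an oxygen on a saturated carbon and a saturated ring carbon. Among the compounds with values here, the step that bears on this is the one from compound 1 to compound 2, which placed a 2-(pyridin-4-yl)ethyl group on the saturated chain carbon bound to an oxygen on a saturated carbon and a saturated ring carbon and lengthened the half-life beyond the scatter; compound 3 changes nothing there and speaks less to it. A step in the same direction, though not certainly of the same size, is therefore expected for compound 4, namely a 2.2-fold higher number from compound 1 to compound 4 (0.34 log units; beyond the scatter). Compound 4 is estimated to give 11 h in this assay, with a range from 5 h to 24 h.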

Compound 4, half-life: 39 h
Beside the measured number, compound 4's estimate is 3.5-fold (0.55 log units) below it; the measured number lies above the stated range.
By their numbers in this assay, from the lowest: compound 3; then compound 1; then compound 2; then compound 4.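

With phenethyl on the saturated chain carbon bound to an oxygen, this assay again shows a longer half-life, a 7.8-fold higher number from compound 1 to compound 4 (0.89 log units; beyond the scatter), in the same direction as the earlier step with 2-(pyridin-4-yl)ethyl, a 2.7-fold higher number from compound 1 to compound 2 (0.44 log units; beyond the scatter). A ring of carbon only therefore suffices for a rise at this position, and a ring nitrogen is not needed for it. Nothing at hand explains why this change lengthens the half-life.

From the compounds shown here alone, compound 2 at 13.7 h and compound 4 at 39 h differ both in the ring and in the configuration drawn at the chain carbon, so the share of each change in their gap stays open. Also open, going by these compounds, is whether a methyl group, or a longer chain ending in an amine, would lengthen the half-life at this position.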